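The source may hold more compounds than are shown below. What is called first, only, known or untested is meant among the compounds shown, and "the series" means these compounds.

Working notes on the series. Compound 1 `Cc1nc(C)n(CC(=O)N2CCN(c3sc(C(F)(F)F)nc3-c3nc4ccc(C5CCOCC5)cc4[nH]3)C[C@H]2C)n1` gives 3.3 nM in a functional assay on CHO-K1 cells for antagonist activity at C-X-C chemokine receptor type 3 (Homo sapiens), read by FLIPR, with a stated time of 10 min, in the presence of a further agent that is not named here; on this read-out higher numbers stand for weaker inhibition and lower numbers for stronger inhibition. Compound 2 `C[C@@H]1CN(c2sc(C(F)(F)F)nc2-c2nc3ccccc3[nH]2)CCN1C(=O)Cn1cc(Cl)cn1` gives 1.7 nM, and compound 3 `C[C@@H]1CN(c2sc(C(F)(F)F)nc2-c2nc3ccccc3[nH]2)CCN1C(=O)Cn1cnc2c1CCN(C)C2` gives 3.6 nM. Compound 3 carries the highest number of the three: compound 1 lies within the scatter of it, while compound 2 lies beyond the scatter, the step being a 2.1-fold higher number from compound 2 to compound 3 (0.33 log units; beyond the scatter). Compound 4 `C[C@@H]1CN(c2sc(C(F)(F)F)nc2-c2nc3ccccc3[nH]2)CCN1C(=O)Cn1ccc(C(=O)O)n1` varies the same position: a group of 8 heavy atoms (4 carbon, 2 nitrogen, 2 oxygen; one five-membered aromatic ring with 2 hetero atoms) in place of a group of 10 heavy atoms (7 carbon, 3 nitrogen; one five-membered aromatic ring with 2 hetero atoms, one six-membered non-aromatic ring with 1 hetero atom), on a saturated chain carbon bound to a carbonyl carbon. Within the data shown here, the only measured step at this place is the one from compound 2 to compound 3, and it was modest, so a modest step is expected here too. Among the measured compounds shown here, the nearest precedent at this position, compound 2 with 1.7 nM, points if anything toward a lower number. For compound 4 the expected value is 2.5 nM, with a range from 0.8 nM to 8 nM, meaning an expected 1.4-fold lower number from compound 3 to compound 4 (0.16 log units; within the scatter).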

Compound 4, half-maximal inhibitory concentration: 2100 nM
Compound 4: middle estimate off by 840-fold (2.92 log units), on the low side; the measured number lies above the stated range.
By their numbers in this assay, from the lowest: compounds 2, 1 and 3 (each within the scatter of the next, the first and the last beyond it); then compound 4.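

The saturated chain carbon bound to a carbonyl carbon does not tolerate every group: the earlier step here was modest, yet 3-carboxy-1H-pyrazol-1-yl gives a 580-fold higher number from compound 3 to compound 4 (2.77 log units; beyond the scatter). With a pyrazole retained, replacing 4-chloro-1H-pyrazol-1-yl gives a 1200-fold higher number from compound 2 to compound 4 (3.09 log units; beyond the scatter), so the pyrazole ring alone does not preserve the low number. Nothing available explains this loss.

Still open, as far as these compounds go, is whether the carboxylic acid itself accounts for the step, or whether its placement on the ring also matters. The corresponding methyl ester, primary amide and 4-carboxy-1H-pyrazol-1-yl group would separate these possibilities.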